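The compounds below may be only part of what the source reports. "The series", "measured", "known", "first", "only" and "open" are said of these compounds alone.

Measured compounds:
compound 1 `COc1cc(C)nc2n/c(=N/C(=O)c3c(-c4ccc(Cl)cc4Cl)noc3C)sn12` gives 26.4%
compound 2 `COc1cc(Cl)nc(NC(=S)NC(=O)c2c(-c3ccc(Cl)cc3Cl)noc2C)n1` gives 30.7%
compound 3 `Cc1onc(-c2ccc(Cl)cc2Cl)c1C(=O)/N=c1/nc2nc(Cl)cc(C)n2s1` gives 20.1%

All three numbers come from a functional assay on the whole organism for inhibition, with Brassica napus as the target, with a stated time of 72 h, tested at 10 mg/L; a lower number here means less inhibition of growth, a higher number more inhibition of growth at the concentration tested. Compound 3 sits at the lowest of the three. Its nearest neighbour is compound 1, whose number is higher but within the scatter, so no order between these two can be read. Compound 2 stands furthest from compound 3, with a gap beyond the scatter. Among the measured compounds shown here, no pair of measured compounds differs in a single place, so no single-point step is available as a guide.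

The next compound, compound 4 `COc1cc(Cl)nc2n/c(=N/C(=O)c3c(-c4ccc(Cl)cc4Cl)noc3C)sn12`, is compound 3 with one change: methoxy in place of methyl on an aromatic carbon. A methoxy group is also present in compound 1 and compound 2, both of which give higher numbers than compound 3, but neither differs from compound 3 only at this point, so those values show no more than that the methoxy-bearing members have so far landed in one general region. In this assay the expected step is small, upward if anything, and not clearly beyond the scatter. The estimated step is a number 5.9 percentage points higher from compound 3 to compound 4 (within the scatter). Compound 4 is expected to give about 26%, in a range from 15% to 38%.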

Compound 4, percent growth inhibition at one concentration: 28.6%
Estimate against measurement, compound 4: 2.6 percentage points below, within the range that was stated.
By their numbers in this assay, from the lowest: compounds 3, 1, 4 and 2 (each within the scatter of the next, the first and the last beyond it).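

Both single-point steps now available lie within the scatter. In this assay, methoxy in place of methyl on an aromatic carbon gives (a number 8.5 percentage points higher from compound 3 to compound 4 (within the scatter)), and chloro in place of methyl on an aromatic carbon gives (a number 2.2 percentage points higher from compound 1 to compound 4 (within the scatter)), so neither exchange yields a readable difference in growth inhibition at the concentration tested, and compound 4 links compound 1 and compound 3 through two exchanges that cannot be told from no effect. Nothing measured here bears on what lies behind these small steps.

Open, going by these compounds, is whether any group at the carbon next to the ring nitrogen can move the number beyond the scatter: an amine, a hydroxyl or a longer alkoxy chain in place of methoxy would test this, as would an amine in place of the chloro group at the other carbon. Also open, on these data alone, is whether the methoxy-for-methyl step keeps its size with methyl rather than chloro on the ring, and how compound 2, which differs from the others in more than one place, relates to the fused compounds.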